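The source may hold more compounds than are shown below. What is called first, only, known or untested is meant among the compounds shown, and "the series" means these compounds.

Working notes on the series, read in a functional assay on MCF7 cells (Homo sapiens) for inhibition, read by MTT assay, with a stated time of 48 h, tested at 10 uM (on this read-out lower numbers stand for less inhibition of growth and higher numbers for more inhibition of growth at the one concentration tested), throughout. Among the measured compounds shown here, compound 1 (`Cc1oc2c([C@H]3CCN(C)C[C@H]3O)c(O)cc(O)c2c(=O)c1C(O)c1ccc([N+](=O)[O-])cc1`) gives 4% and compound 2 (`COc1ccc(C(O)c2c(C)oc3c([C@H]4CCN(C)C[C@H]4O)c(O)cc(O)c3c2=O)cc1Br`) gives 41% as the higher of the two numbers so far. Compound 3 (`CCOc1ccc(Br)c(C(O)c2c(C)oc3c([C@H]4CCN(C)C[C@H]4O)c(O)cc(O)c3c2=O)c1`) is still unmeasured. It differs from compound 2 as follows: 2-bromo-5-ethoxyphenyl in place of 3-bromo-4-methoxyphenyl on a saturated chain carbon bound to an aromatic carbon and an oxygen on a saturated carbon (2-bromo-5-ethoxyphenyl in place of 3-bromo-4-methoxyphenyl, on a saturated chain carbon bound to an aromatic carbon and an oxygen on a saturated carbon). For the measured compounds named here, only one measured step bears on this place, the large one beyond the scatter, a number 37 percentage points higher from compound 1 to compound 2 (beyond the scatter) (a swap of 4-nitrophenyl for 3-bromo-4-methoxyphenyl). That step shows the group here can matter, but the present swap keeps bromine and an alkoxy oxygen, so a smaller move is expected. For compound 3 a modest fall is expected, estimated as a number 8 percentage points lower from compound 2 to compound 3 (within the scatter) and probably not beyond the scatter. For compound 3 the estimated value is 33% (expected range 12% to 56%).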

Compound 3, percent growth inhibition at one concentration: 9%
For compound 3 the middle estimate is 24 percentage points above the measured one; measured number below the stated range.
By their numbers in this assay, from the lowest: compounds 1 and 3 (each within the scatter of the next); then compound 2.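

In this assay, keeping bromine and an alkoxy oxygen on the aryl group does not by itself hold the number, with a number 32 percentage points lower from compound 2 to compound 3 (beyond the scatter). The 2-bromo-5-ethoxyphenyl group also gives no separation from 4-nitrophenyl, with a number 5 percentage points higher from compound 1 to compound 3 (within the scatter), so among the three compounds the higher number at this place belongs to 3-bromo-4-methoxyphenyl alone and not to bromo-alkoxy aryl groups in general. No measurement at hand gives a reason for the large step from the 3-bromo-4-methoxyphenyl group.

This step changes where the bromine and alkoxy groups sit and replaces methoxy with ethoxy at once, and the compounds shown do not separate these two changes. Also open, from the compounds shown here alone, is how an aryl group carrying an amine or a carboxylic acid would read at this place.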